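Notes on the step from compound 3 to compound 4

This account rests on a few compounds, and the source may have more. Where it says the series, first, only, none or still open, it means among the compounds named here.

Three compounds of this series carry numbers in a functional assay (aorta) with Rattus norvegicus as the target; a lower number here means a stronger inhibitor, a higher number a weaker inhibitor. Compound 1 `COC(=O)c1cc2ccccc2n1[C@@H]1c2cc(C#N)ccc2OC(C)(C)[C@H]1O` gives 33000 nM in this assay. Compound 2 `CCOC(=O)CN(c1ccccc1)[C@@H]1c2cc(C#N)ccc2OC(C)(C)[C@H]1O` returns only > 30000 nM in this assay, which is a limit and not a number. Compound 3 `CCOC(=O)CCCN(c1ccccc1)[C@H]1c2cc(C#N)ccc2OC(C)(C)[C@@H]1O` likewise returns only > 30000 nM in this assay, again a limit rather than a number. For the measured compounds named here, compound 3 therefore has no number to stand on; it sits at the limit of > 30000 nM in this assay, at which 2 of the 3 values shown sit, and no step between two measured compounds is available to calibrate the change that follows.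

Compound 4 `Cc1noc(CN(c2ccccc2)[C@H]2c3cc(C#N)ccc3OC(C)(C)[C@@H]2O)n1` is the next member to be tested. It differs from compound 3 by 3-methyl-1,2,4-oxadiazol-5-yl in place of 2-(ethoxycarbonyl)ethyl on a saturated chain carbon bound to a nitrogen on an aromatic ring. Going by the values given here, no measured pair shows a change of this kind, and the weak end of the series offers no direction to read from it. The expectation for this assay is therefore a step of no size beyond the scatter in either direction, with a high chance that compound 4 again returns only a limit. Compound 4 is estimated at 30000 nM, with a range from 10000 nM to 100000 nM. The step this estimate implies is expected to be a number no higher from compound 3 to compound 4 (the limit leaves the size open).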

Compound 4, half-maximal inhibitory concentration: > 30000 nM
Compound 4: only a limit was reported (the forecaster's own chance of this, stated with the estimate: 60%); the middle value lies on the limit itself.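

For the compounds shown here, compound 3 and compound 4 both return only a limit in this assay, so no step between them can be read. The compounds shown leave open whether 3-methyl-1,2,4-oxadiazol-5-yl in place of 2-(ethoxycarbonyl)ethyl changes the inhibitory value at all, with most of the series resting on one mark: the limit of > 30000 nM in this assay, at which 3 of the 4 values shown sit.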